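From acetyl to a longer ester on compound 2

The compounds below may be only part of what the source reports. "The series", "measured", "known", "first", "only" and "open" are said of these compounds alone.

Compound 1 `O=C1NC(O)C(F)=CN1[C@H]1C=C[C@@H](CO)O1`: 63000 nM
Compound 2 `CC(=O)OC[C@@H]1C=C[C@H](n2cc(F)c(N)nc2=O)O1`: > 100000 nM (a limit)

In a functional assay on PC-3 cells (Homo sapiens) for antiproliferative activity (on this read-out lower numbers stand for stronger inhibition and higher numbers for weaker inhibition), compound 2 gives only a limit, > 100000 nM. Compound 3 `CCCCC(=O)OC[C@@H]1C=C[C@H](n2cc(F)c(N)nc2=O)O1` differs from it in one place: propyl in place of hydrogen on a saturated chain carbon bound to a carbonyl carbon, or acetoxy to (butylcarbonyl)oxy. Within the data shown here, no measured step shows what such a change does. Among the measured compounds shown here, the only exact number, compound 1 at 63000 nM, serves as a rough guide. The expected at least 1.6-fold lower number from compound 2 to compound 3 (0.22 log units; that floor lies within the scatter) is modest, toward stronger inhibition, and may stay within the scatter. Compound 3 is estimated at 60000 nM, with an expected range of 15000 nM to 200000 nM.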

Compound 3, half-maximal inhibitory concentration: > 100000 nM
Compound 3: only a limit was reported; the forecaster's own chance of this, stated with the estimate: 45%; middle value at least 1.6-fold (0.22 log units) away from the limit.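

Compound 2 and compound 3 both give only a limit in this assay, so no step can be read between them: the limit of > 100000 nM in this assay, at which 2 of the 3 values shown sit.

The compounds shown leave open whether going from acetoxy to (butylcarbonyl)oxy changes antiproliferative activity at all.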